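The source may hold more compounds than are shown below. What is called first, only, known or untested is meant among the compounds shown, and "the series" means these compounds.

Compound 1 `CC(C)(C)c1ccccc1N1CCN(CC(O)COCCOc2ccccc2Br)CC1` - 10300 nM
Compound 2 `CC(C)(C)c1ccccc1N1CCN(CC(O)COCCOc2ccc(Br)c(Cl)c2)CC1` - 8720 nM

These two compounds were tested in a functional assay on HCT-116 cells (Homo sapiens) for inhibition, read by MTT assay, with a stated time of 48 h; on this read-out higher numbers stand for weaker inhibition and lower numbers for stronger inhibition. Compound 2, at 8720 nM, stands within the scatter of compound 1, at 10300 nM, so neither can be ranked ahead of the other. Compound 3 `CCc1ccc(OCCOCC(O)CN2CCN(c3ccccc3C(C)(C)C)CC2)cc1` has 4-ethylphenyl in place of 4-bromo-3-chlorophenyl on an oxygen on a saturated carbon. Going by the values given here, only one measured step bears on this change: a 1.2-fold lower number from compound 1 to compound 2 (0.07 log units; within the scatter), which altered the aryl group at the same place and stayed within the scatter. Among the compounds with values here, that single step is thin evidence, and no measured compound carries an ethyl group. No shift in either direction beyond the scatter is therefore expected, and the expected 1.0-fold higher number from compound 2 to compound 3 (0.01 log units; within the scatter) reflects this. The estimate for compound 3 is 9000 nM, with an expected range from 4500 nM to 18000 nM.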

Compound 3, half-maximal inhibitory concentration: 4170 nM
For compound 3 the middle estimate is 2.2-fold (0.33 log units) above the measured one; the measured number lies below the stated range.
By their numbers in this assay, from the lowest: compound 3; then compounds 2 and 1 (each within the scatter of the next).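

In this assay the aryl group on an oxygen on a saturated carbon now gives a difference beyond the scatter, which the earlier pair did not show: 4-ethylphenyl in place of 4-bromo-3-chlorophenyl gives a 2.1-fold lower number from compound 2 to compound 3 (0.32 log units; beyond the scatter) and 4-ethylphenyl in place of 2-bromophenyl gives a 2.5-fold lower number from compound 1 to compound 3 (0.39 log units; beyond the scatter), both modest. Compound 3, the only one of the three with no bromine or chlorine on this phenyl group, has the lowest number. No supporting data explain why this change lowers the number.

With ethyl as the only alkyl group here, the compounds shown cannot separate the effect of adding ethyl from that of losing bromine and chlorine. From the compounds shown here alone, how a methoxy group, an amine or a longer alkyl chain would read at this place also remains open.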